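This account rests on a few compounds, and the source may have more. Where it says the series, first, only, none or still open, it means among the compounds named here.

Compound 1, `CSc1nc2c(C)nsc2n1[C@H]1C[C@H](O)[C@@H](CO)O1`. In a functional assay on HFF cells (Homo sapiens) for inhibition (on this read-out higher numbers stand for weaker inhibition and lower numbers for stronger inhibition), compound 1 gives > 100000 nM, which is a limit of the assay and not a number.
Compound 2, `CSc1nc2cnsc2n1[C@H]1C[C@H](O)[C@@H](CO)O1`. In this assay compound 2 gives > 100000 nM, again a limit of the assay.
Compound 3, `OC[C@H]1O[C@@H](n2c(SCc3ccccc3)nc3cnsc32)C[C@@H]1O`. In this assay compound 3 gives > 100000 nM, also a limit of the assay.

Compound 2 thus stands only at a limit, as do the two other measured compounds. The two measured steps that touch it, a step that the two limits leave unreadable from compound 1 to compound 2 and a step that the two limits leave unreadable from compound 2 to compound 3, cannot be sized because of the limit of > 100000 nM in this assay, at which 3 of the 3 values shown sit. Compound 4, `CSc1nc2cnsc2n1[C@@H]1O[C@H](CO)[C@@H](O)[C@H]1O`, differs from compound 2 by hydroxy in place of hydrogen on a saturated ring carbon. Neither measured step gives a readable size, so no direction can be drawn from them, and the expectation rests on compound 2 alone. Compound 4 is therefore expected to remain at the limit, a number no higher from compound 2 to compound 4 (the limit leaves the size open). The estimate for compound 4 is 100000 nM, with a range from 30000 nM to 300000 nM.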

Compound 4, half-maximal inhibitory concentration: > 100000 nM
Compound 4: a limit, no number (the forecaster's own chance of this, stated with the estimate: 85%); the middle value lies on the limit itself.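

Compound 2 and compound 4 both stand only at a limit, so no size can be read for the change between them: the limit of > 100000 nM in this assay, at which 4 of the 4 values shown sit. The compounds shown leave open which structural change, if any, would bring a measurable value in this assay.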